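The compounds below may be only part of what the source reports. "The series", "measured", "known", "first", "only" and "open" are said of these compounds alone.

Of the compounds shown here, three have been tested in a functional assay on PC-3 cells (Homo sapiens) for cytotoxicity, read by MTT assay, with a stated time of 72 h; a higher number here means a weaker inhibitor, a lower number a stronger inhibitor. Compound 1 `[O-][n+]1nc(NCOC2CCCCC2)[n+]([O-])c2ccccc21` gives 6670 nM, compound 2 `CCCCCOCNc1n[n+]([O-])c2ccccc2[n+]1[O-]` gives 8510 nM, and compound 3 `COc1ccc(COCNc2n[n+]([O-])c3ccccc3[n+]2[O-])cc1` gives 52800 nM, the highest of the three numbers. The next compound, compound 4 `CCCOCNc1n[n+]([O-])c2ccccc2[n+]1[O-]`, differs from compound 3 in one place: ethyl in place of 4-methoxyphenyl on a saturated chain carbon bound to an oxygen on a saturated carbon. The relevant earlier step, a 6.2-fold higher number from compound 2 to compound 3 (0.79 log units; beyond the scatter), went the opposite way, from a straight chain to the same aryl group, so the present change is expected to bring the number back down, since a 1.3-fold higher number from compound 1 to compound 2 (0.11 log units; within the scatter) suggests that swapping one simple alkyl group for another shifts little. The step of a 5.9-fold lower number from compound 3 to compound 4 (0.77 log units; beyond the scatter) is therefore expected. Compound 4 is estimated at 9000 nM, with a range from 4000 nM to 20000 nM.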

Compound 4, half-maximal inhibitory concentration: 7400 nM
Compound 4: middle estimate off by 1.2-fold (0.09 log units), on the high side; the measured number falls inside the stated range.
By their numbers in this assay, from the lowest: compounds 1, 4 and 2 (each within the scatter of the next); then compound 3.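

Swapping 4-methoxyphenyl for ethyl in this assay reverses the earlier rise (a 7.1-fold lower number from compound 3 to compound 4 (0.85 log units; beyond the scatter)), so a second chain compound now stands well apart from the aryl compound. Among the non-aryl groups, the shorter chain (a 1.2-fold lower number from compound 2 to compound 4 (0.06 log units; within the scatter)) and the swap from cyclohexyl to propyl (a 1.1-fold higher number from compound 1 to compound 4 (0.05 log units; within the scatter)) leave the numbers indistinguishable. No available data explain why the aryl compound differs.

Going by these compounds, it remains open whether the ring itself or its methoxy goes with the higher number, which a plain phenyl in this place could test. A chain carrying an amine could show whether this tolerance extends beyond simple alkyl groups.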